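The source may hold more compounds than are shown below. What is called first, only, known or untested is meant among the compounds shown, and "the series" means these compounds.

Measured so far: compound 1, `Nc1scc(CN2CCN(c3cccc(C(F)(F)F)c3)CC2)c1C(=O)c1ccc(Cl)cc1`, with -80% in a functional assay on CHO cells with adenosine receptor A1 (Homo sapiens) as the target, read by cAMP accumulation and immunoassay, with a stated time of 6 min, tested at 10 uM; a lower number here means a stronger effect, a higher number a weaker effect of the compound at the concentration tested; compound 2, `Nc1scc(CN2CCN(c3c(F)cccc3F)CC2)c1C(=O)c1cccc(C(F)(F)F)c1`, with 4% in this assay.

Of the two numbers available, compound 1 stands lowest, and compound 2 lies a long way higher, a gap well beyond the usual scatter of this measurement. For the measured compounds named here, the two compounds differ in more than one place, so no single step can be drawn between them; their values show only that one arrangement of the shared core gives a strong effect and the other almost none.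

Compound 3, `Nc1scc(CN2CCN(c3ccc(F)c(F)c3)CC2)c1C(=O)c1ccc(Cl)cc1`, has not yet been measured. It differs from compound 1 in one place: 3,4-difluorophenyl in place of 3-(trifluoromethyl)phenyl on an amine nitrogen in a ring. Going by the values given here, since no single-point step between measured compounds is known, the size of the step can only be guessed. Among the compounds with values here, compound 2, the only other compound, carries a fluorinated aryl on the same amine nitrogen in a ring and gives 4%, which suggests the effect may weaken, though that compound also differs elsewhere.

A moderate weakening is expected, a number 40 percentage points higher from compound 1 to compound 3 (beyond the scatter). For compound 3 the estimate is -40%, with a range from -85% to 10%.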

Compound 3, a percentage reported as activity, at one concentration (the size of the read-out at that concentration, not a potency): -87%
The estimate for compound 3 lay 47 percentage points above the measured number; measured number outside the range, below it.
By their numbers in this assay, from the lowest: compounds 3 and 1 (each within the scatter of the next); then compound 2.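

In this assay, for the compounds shown here, 3,4-difluorophenyl in place of 3-(trifluoromethyl)phenyl on an amine nitrogen in a ring gives a number 7 percentage points lower from compound 1 to compound 3 (within the scatter), the first step at this position that changes one place only. The strong effect seen with compound 1 therefore does not require the trifluoromethyl group: an aryl group with two fluorines and 8 heavy atoms serves equally well in this assay. Compound 3 also shows that a fluorinated aryl group on this nitrogen can go with a strong effect, so the weak value of compound 2 cannot be read as a general result for such groups. No data at hand explain why the two groups give values within the scatter of each other.

On these data alone, it remains open whether the effect persists with a different group on this nitrogen, such as an unsubstituted phenyl, a methoxyphenyl or a benzyl group. Going by these compounds alone, also open is how the value of compound 2 arises, as it differs from compound 1 and compound 3 in more than one place and no single step connects them.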